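A few compounds are considered here, and "the series" means these few. Any claim that something is new, unique, unknown or untested is made for them only; others in the source may bear on it.

Measured in a functional assay on MDA-MB-231 cells (Homo sapiens) for cytotoxicity, read by MTT assay, with a stated time of 72 h; on this read-out lower numbers stand for stronger inhibition and higher numbers for weaker inhibition:
- compound 1 `O=C(CN1CCN(c2nnc(Cc3ccccc3)c3ccccc23)CC1)Nc1ccc(F)c(C(F)(F)F)c1`: 760 nM
- compound 2 `Cc1ccc(F)cc1NC(=O)CN1CCN(c2nnc(Cc3ccccc3)c3ccccc23)CC1`: 19200 nM
- compound 3 `Cc1ccc(F)cc1NC(=O)CN1CCN(c2nnc(Cc3ccncc3)c3ccccc23)CC1`: 6.4 nM

Among these three, compound 3 gives the lowest number, 6.4 nM, and its gaps to compound 1 and compound 2 lie beyond the scatter. Compound 4 `Cc1cccc(Cl)c1NC(=O)CN1CCN(c2nnc(Cc3ccncc3)c3ccccc23)CC1` differs from compound 3 by a single change: 2-chloro-6-methylphenyl in place of 5-fluoro-2-methylphenyl on an amide-type nitrogen.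

Among the compounds with values here, two measured steps bear on this change. The closer one is a 25-fold higher number from compound 1 to compound 2 (1.40 log units; beyond the scatter). It also swaps the group on the amide-type nitrogen, so this place can clearly move the number a long way. However, that step involves other groups and a phenyl in place of the pyridin-4-yl, so it gives no direction here. The other step is a 3000-fold lower number from compound 2 to compound 3 (3.48 log units; beyond the scatter), which brings in the pyridin-4-yl group that compound 4 keeps, so compound 4 is expected to stay well below compound 2. Within the data shown here, no measured compound carries 2-chloro-6-methylphenyl. Since compound 3 already has the lowest number, with 6.4 nM, a rise looks likelier than a further drop. The expected change is a 7.8-fold higher number from compound 3 to compound 4 (0.89 log units; beyond the scatter), a moderate step with much uncertainty. For compound 4 the estimate is 50 nM, with an expected range of 5 nM to 500 nM.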

Compound 4, half-maximal inhibitory concentration: 2670 nM
For compound 4 the middle estimate is 53-fold (1.73 log units) below the measured one; the whole stated range lies below it.
By their numbers in this assay, from the lowest: compound 3; then compound 1; then compound 4; then compound 2.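

In this assay the change to 2-chloro-6-methylphenyl gives a 420-fold higher number from compound 3 to compound 4 (2.62 log units; beyond the scatter) with the pyridin-4-yl group left in place, so the group on the amide-type nitrogen still moves the number a long way in this series. Within the data shown here, the earlier swap at this place (a 25-fold higher number from compound 1 to compound 2 (1.40 log units; beyond the scatter)) was seen only with a phenyl group on the chain carbon, so large steps at this position now appear with both phenyl and pyridin-4-yl, and keeping pyridin-4-yl does not by itself ensure a number as low as that of compound 3. The two groups match in heavy-atom count, ring type and hydrogen-bond donor and acceptor counts, so those counts do not separate them, and no measurement here accounts for the rise.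

This single change replaces fluorine with chlorine and also alters the substitution pattern of the ring, so the compounds shown cannot say which of these matters. Also open, as far as these compounds go, is how a plain phenyl or a 2-methylphenyl group on the amide-type nitrogen would read alongside the pyridin-4-yl group.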